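Changing the Ring on the Carbonyl Carbon

The source may report more compounds than this note shows. Statements on the series, on what has been measured and on what is new or still open speak of the compounds shown alone.

Compound 1: `COc1cc(-c2cc(/C=C/C(=O)c3ccc(Cl)c(Cl)c3)[nH]n2)cc(OC)c1OC`, giving -9%
Compound 2: `COc1ccc(C(=O)/C=C/c2cc(-c3cc(OC)c(OC)c(OC)c3)n[nH]2)cc1`, giving -64%

Of the compounds shown here, two have been measured in a functional assay on HOP-62 cells (Homo sapiens) for cytotoxicity, read by sulforhodamine B assay, with a stated time of 48 h, tested at 10 uM; on this read-out lower numbers stand for a stronger effect and higher numbers for a weaker effect at the one concentration tested. In this assay compound 1 gives -9%, while compound 2 gives -64%, the lowest of the two numbers; its nearest neighbour is compound 1, and the step of a number 55 percentage points lower from compound 1 to compound 2 (beyond the scatter) lies beyond the scatter.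

Compound 3, `COc1cc(-c2cc(/C=C/C(=O)c3ccc(F)c(F)c3)[nH]n2)cc(OC)c1OC`, has not yet been measured. It differs from compound 2 in one place: 3,4-difluorophenyl in place of 4-methoxyphenyl on a carbonyl carbon. The only measured step that bears on this change is the one already shown, a number 55 percentage points lower from compound 1 to compound 2 (beyond the scatter), in which a 3,4-dichlorophenyl group on the carbonyl carbon gave way to 4-methoxyphenyl and the number fell by a large amount. The change to compound 3 runs in the opposite sense, putting a 3,4-difluorophenyl group in place of the 4-methoxyphenyl, so a rise in this assay is expected, though a smaller one is judged likely for compound 3 since a difluorophenyl is not a dichlorophenyl. Compound 3 is therefore estimated at -30%, within -62% to 5%, an expected step of a number 34 percentage points higher from compound 2 to compound 3 (beyond the scatter).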

Compound 3, a percentage reported as activity, at one concentration (the size of the read-out at that concentration, not a potency): 25%
Estimate against measurement, compound 3: 55 percentage points below, outside the stated range (above it).
By their numbers in this assay, from the lowest: compound 2; then compound 1; then compound 3.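

Among these compounds, the ring on the carbonyl carbon turns out to span a wider range in this assay than the first pair suggested, and the largest step so far is a number 89 percentage points higher from compound 2 to compound 3 (beyond the scatter). Among the compounds shown here, the two halogen-bearing rings are also not interchangeable at this position: exchanging chlorine for fluorine on the 3,4-disubstituted ring gives a number 34 percentage points higher from compound 1 to compound 3 (beyond the scatter) and puts compound 3 at 25%, the only positive number of the three, so this one place moves the read-out from the lowest number with 4-methoxyphenyl to the highest with 3,4-difluorophenyl. No measurement is at hand that could explain why these rings rank as they do, or why the two halogens differ so widely on an otherwise unchanged compound.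

For the compounds shown here, with only three rings compared, it remains open where a plain phenyl, a 4-aminophenyl or a 3,4-dimethoxyphenyl group on the carbonyl carbon would fall in this order. Because each compound has a reading at a single concentration in one cell line, the compounds shown also leave open whether the same order would hold across a range of concentrations or in other cells.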